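The compounds below may be only part of what the source reports. "The series", "measured", "known", "first", "only" and "open" are said of these compounds alone.

Of the compounds shown here, three have been measured in an ADME assay on Vero cells (Chlorocebus sabaeus) for cytotoxicity, with a stated time of 72 h, tested at 10 ug/mL; a higher number here means a stronger effect of the compound at the concentration tested, a lower number a weaker effect. Compound 1, whose structure is `Cc1ccc(N2CCN/C2=N\N)cc1`, gives 0%. Compound 3, with the structure `N/N=C1\NCCN1c1ccccc1`, gives 0%. Compound 2, with the structure `Cc1ccc(N2CCn3c2n[nH]c(=O)c3=N)cc1`, gives 0%. The difference between the core of compound 1 and the core of compound 2 is not broken down here. Compound 2 stands level with compound 1 and with compound 3 at the digits reported, and within the usual scatter of such measurements no difference among the three can be read off.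

From compound 1 to compound 3 the change is hydrogen in place of methyl on an aromatic carbon. The step of no change at the digits printed from compound 1 to compound 3 (within the scatter) stays flat.

Compound 4 has not yet been measured; its structure is `N=c1c(=O)[nH]nc2n1CCN2c1ccccc1`. From compound 2 to compound 4 the change is hydrogen in place of methyl on an aromatic carbon. It is the same kind of change as that from compound 1 to compound 3, though the surroundings of the place are described differently: in compound 2 the methyl sits para to a large group, whereas in compound 1 it sits para to a group of 7 heavy atoms. Among the measured compounds shown here, with the shared core of compound 2 and compound 4 remaining the same and only this change made, the step from compound 2 to compound 4 is expected to be no change at the digits printed from compound 2 to compound 4 (within the scatter), placed beside no change at the digits printed from compound 1 to compound 3 (within the scatter). This expectation rests on the flat step from compound 1 to compound 3 and on compound 2 giving 0%. In this assay compound 4 is therefore estimated at 0%, with a likely range from 0% to 10%.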

Compound 4, a percentage reported as inhibition, at one concentration (the size of the read-out at that concentration, not a potency): 26%
Estimate against measurement, compound 4: 26 percentage points below; the measured number lies above the stated range.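

In this assay, putting hydrogen in place of methyl on an aromatic carbon gives a number 26 percentage points higher from compound 2 to compound 4 (beyond the scatter), so on this core the swap is not neutral. This does not show why the core matters, since the two cores differ in ways that these pairs do not separate, and a single pair on each core cannot give a rule for a third core; the read-out also comes from one concentration and is not a potency. What can be said is that a result for this swap on one core cannot simply be assumed to hold on the other, as the two pairs side by side make plain: the same change on two cores in this assay, no change at the digits printed (within the scatter) from compound 1 to compound 3 and a number 26 percentage points higher (beyond the scatter) from compound 2 to compound 4, 26 percentage points apart, beyond the scatter of two such steps

The compounds shown leave open how a chlorine atom, a methoxy group or a longer chain such as ethyl would read at this same place on either core in this assay. They also leave open whether the higher number seen with hydrogen on the core of compound 4 would persist if the core itself were altered, for example by replacing its carbonyl with another group.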